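Replacing 6-hydroxypyridin-3-yl with pyridin-4-yl on a shared core

The source may hold more compounds than are shown below. What is called first, only, known or untested is meant among the compounds shown, and "the series" means these compounds.

Of the compounds shown here, two built on the same core have so far been measured in an assay on HeLa cells for inhibition of Kinesin-like protein KIF15 (Homo sapiens), read by microscopy, with stated times of 2 s and 20 s, tested at 750 nM; on this read-out lower numbers stand for less inhibition and higher numbers for more inhibition at the one concentration tested (going by the name of the read-out). Compound 1 `O=C1Nc2ccc(C(=O)c3ccco3)cc2/C1=C/c1cc(I)c(O)c(I)c1` gives 26%, and compound 2 `O=C1Nc2ccc(C(=O)c3ccco3)cc2/C1=C/c1ccc(O)nc1` gives 26.5%. Within the data shown here, the step between them, a number 0.5 percentage points higher from compound 1 to compound 2 (within the scatter), is too small to count as a real difference, so compound 2 stands level with its only measured neighbour rather than above or below it. Compound 3 `O=C1Nc2ccc(C(=O)c3ccco3)cc2/C1=C/c1ccncc1` is the next member of the series. It differs from compound 2 in one place only: pyridin-4-yl in place of 6-hydroxypyridin-3-yl on a double-bonded chain carbon bound to a double-bonded ring carbon. Among the measured compounds shown here, the only measured step bearing on this position is the one from the diiodophenyl group to the hydroxypyridine ring, where a number 0.5 percentage points higher from compound 1 to compound 2 (within the scatter) left the read-out essentially unchanged. A similar outcome is expected here, with a step no larger than the scatter, a number 3.5 percentage points lower from compound 2 to compound 3 (within the scatter). Compound 3 is therefore estimated at 23%, within a range from 5% to 40%.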

Compound 3, a percentage reported as inhibition, at one concentration (the size of the read-out at that concentration, not a potency): 0.8%
Compound 3: middle estimate off by 22.2 percentage points, on the high side, and the stated range ends above it.
By their numbers in this assay, from the lowest: compound 3; then compounds 1 and 2 (each within the scatter of the next).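

In this assay, this position proves sensitive to the group it carries: the two earlier groups stood level despite their different rings, but pyridin-4-yl gives a number 25.7 percentage points lower from compound 2 to compound 3 (beyond the scatter) and a number 25.2 percentage points lower from compound 1 to compound 3 (beyond the scatter). Among these three compounds, the higher read-outs belong to compound 1 and compound 2, whose groups both carry a hydroxy group, while the pyridin-4-yl group of compound 3 has none. The change from 6-hydroxypyridin-3-yl also moves the point of attachment on the pyridine ring, so the hydroxy group cannot be singled out, and no supporting data explain the drop.

A 4-hydroxyphenyl or pyridin-3-yl group at this position could help separate the two changes. Going by these compounds, it also remains open whether an amino group could take the place of the hydroxy group.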